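The source may hold more compounds than are shown below. What is called first, only, known or untested is meant among the compounds shown, and "the series" means these compounds.

In a functional assay, with a stated time of 6 min (on this read-out lower numbers stand for stronger inhibition and higher numbers for weaker inhibition), three compounds that share a core and differ in the group on an amine nitrogen have been measured. Compound 1 (`CCOc1ccccc1NCn1nc(-c2ccc3c(c2)OCCO3)oc1=S`), with 2-ethoxyphenyl, gives 5280 nM. Compound 2 (`S=c1oc(-c2ccc3c(c2)OCCO3)nn1CNC1CCCCC1`), with cyclohexyl, gives 18400 nM. Compound 3 (`S=c1oc(-c2ccc3c(c2)OCCO3)nn1CNc1ccc(Cl)cc1Cl`), with 2,4-dichlorophenyl, gives 8710 nM. Its number stands close to that of compound 1, as a 1.6-fold higher number from compound 1 to compound 3 (0.22 log units; within the scatter) shows, and apart from that of compound 2, as a 2.1-fold lower number from compound 2 to compound 3 (0.32 log units; beyond the scatter) shows.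

Compound 4 (`S=c1oc(-c2ccc3c(c2)OCCO3)nn1CNc1cccc(Br)c1`) has 3-bromophenyl in place of 2,4-dichlorophenyl on an amine nitrogen. Among the compounds with values here, no compound measured so far carries 3-bromophenyl, so the evidence is indirect. Within the data shown here, the closest precedent is the exchange of one substituted phenyl group for another, which stayed small in a 1.6-fold higher number from compound 1 to compound 3 (0.22 log units; within the scatter). Among the measured compounds shown here, the only sizeable change, a 3.5-fold higher number from compound 1 to compound 2 (0.54 log units; beyond the scatter), replaced a phenyl group with cyclohexyl, and compound 4 involves no such replacement. With three measured compounds, this remains a thin basis, so a wide range is appropriate. No step beyond the scatter is therefore expected in this assay, and the estimate corresponds to a 1.1-fold lower number from compound 3 to compound 4 (0.04 log units; within the scatter). For compound 4 the expected value is 8000 nM, with an estimated range from 3500 nM to 18000 nM.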

Compound 4, half-maximal inhibitory concentration: 10800 nM
Compound 4: the middle estimate sits 1.4-fold (0.13 log units) below what was measured; low and high end bracket the measured number.
By their numbers in this assay, from the lowest: compounds 1, 3, 4 and 2 (each within the scatter of the next, the first and the last beyond it).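

In this assay, exchanging 2,4-dichlorophenyl for 3-bromophenyl on the amine nitrogen (a 1.2-fold higher number from compound 3 to compound 4 (0.09 log units; within the scatter)) leaves the result within the scatter, so this position accepts a second halogen-bearing phenyl group, with a different halogen and substitution pattern, without a step that can be read. The new compound also changes what the earlier comparison with cyclohexyl suggested: compound 3 stood apart from compound 2, but 3-bromophenyl does not (a 1.7-fold lower number from compound 2 to compound 4 (0.23 log units; within the scatter)), so a phenyl group in this place does not by itself separate a compound from the cyclohexyl analogue, and compound 4 goes against any such pattern, while the modest step to 3-bromophenyl from 2-ethoxyphenyl (a 2.0-fold higher number from compound 1 to compound 4 (0.31 log units; beyond the scatter)) lies just beyond the scatter and leaves compound 1 apart from both compound 2 and compound 4, though not from compound 3. Nothing available gives a reason for any of these steps.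

The compounds shown do not separate the identity of the halogen from its place on the ring, as 2,4-dichlorophenyl and 3-bromophenyl differ in both. They also leave open how unsubstituted phenyl, or a phenyl ring bearing a carboxylic acid or an amine, would behave on this nitrogen.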